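Thienoimidazole-pyrimidine amides: cytotoxicity on A-375 cells

This account rests on a few compounds, and the source may have more. Where it says the series, first, only, none or still open, it means among the compounds named here.

Measured so far:
compound 1, `O=C(NCCCNc1nccc(-c2c(-c3cccc(F)c3)nc3sccn23)n1)c1ccc(Cl)cc1`, 13700 nM
compound 2, `Cc1ccc(C(=O)NCCNc2nccc(-c3c(-c4cccc(F)c4)nc4sccn34)n2)cc1`, 5880 nM

Both compounds share the same core and differ only in the amide-bearing side chain. Going by the values given here, in a functional assay on A-375 cells (Homo sapiens) for cytotoxicity, read by MTT assay (on this read-out lower numbers stand for stronger inhibition and higher numbers for weaker inhibition), compound 2 gives 5880 nM, the lowest of the two numbers; compound 1 gives 13700 nM, and the only measured step, a 2.3-fold lower number from compound 1 to compound 2 (0.37 log units; beyond the scatter), separates them.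

Compound 3, `O=C(NCCCNc1nccc(-c2c(-c3cccc(F)c3)nc3sccn23)n1)c1ccc(F)cc1`, is not yet measured. It differs from compound 2 by (((4-fluorophenyl)carbonyl)amino)methyl in place of ((4-methylphenyl)carbonyl)amino on a saturated chain carbon, two bonds along the chain from a nitrogen on an aromatic ring. This change largely runs back along the measured step: compound 3 returns to the chain arrangement of compound 1 and again carries a halogen on the benzamide ring, while compound 1 and compound 3 differ only in which halogen that is. Among the compounds with values here, the one relevant step, a 2.3-fold lower number from compound 1 to compound 2 (0.37 log units; beyond the scatter), was modest, so the reverse is expected to be of similar size. A modest rise in the number is therefore expected, a 1.7-fold higher number from compound 2 to compound 3 (0.23 log units; within the scatter), landing compound 3 near compound 1. Compound 3 is estimated at 10000 nM, with a range from 4000 nM to 25000 nM.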

Compound 3, half-maximal inhibitory concentration: 14900 nM
Compound 3: the middle estimate sits 1.5-fold (0.17 log units) below what was measured; the measured number falls inside the stated range.
By their numbers in this assay, from the lowest: compound 2; then compounds 1 and 3 (each within the scatter of the next).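

In this assay, fluoro in place of chloro on an aromatic carbon gives a 1.1-fold higher number from compound 1 to compound 3 (0.04 log units; within the scatter), so these two halogens cannot be told apart at this site. The change from compound 2 now has two counterparts, since (((4-fluorophenyl)carbonyl)amino)methyl in place of ((4-methylphenyl)carbonyl)amino gives a 2.5-fold higher number from compound 2 to compound 3 (0.40 log units; beyond the scatter), a modest step of similar size to a 2.3-fold lower number from compound 1 to compound 2 (0.37 log units; beyond the scatter), and both halogen compounds stand on the higher side of compound 2. No measurement at hand accounts for either step.

Each step from compound 2 changes the chain and the group on the aromatic ring of the amide together, so the compounds shown cannot assign the difference to either one, and the two halogen compounds share a single chain. A methyl-bearing aromatic ring on the chain of compound 1, a halogen-bearing aromatic ring on the chain of compound 2, or a longer chain would help separate the two contributions, and a methoxy group or a nitrile in place of the halogen would test whether the aromatic carbon tolerates more than fluoro and chloro.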